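Ethynyl substituent changes on the shared core

The compounds below may be only part of what the source reports. "The series", "measured", "known", "first", "only" and "open" are said of these compounds alone.

Working notes on a short series of 2-alkynyl analogues. Compound 1 is `CNC(=O)[C@@]12C[C@@H]1[C@@H](n1cnc3c(NC)nc(C#Cc4ccccc4OC)nc31)[C@H](O)[C@@H]2O`; in an assay on CHO cells for displacement of a labelled ligand from adenosine receptor A1 (Homo sapiens), read by scintillation counting, with a stated time of 60 min, tested at 10 uM (on this read-out higher numbers stand for more inhibition at the one concentration tested (going by the name of the read-out) and lower numbers for less inhibition), compound 1 gives 12%. Compound 2 is `CNC(=O)[C@@]12C[C@@H]1[C@@H](n1cnc3c(NC)nc(C#Cc4cnn(C)c4)nc31)[C@H](O)[C@@H]2O`, and in this assay compound 2 gives 35%. For the measured compounds named here, the single measured step, a number 23 percentage points higher from compound 1 to compound 2 (beyond the scatter), follows the exchange of 2-methoxyphenyl for 1-methyl-1H-pyrazol-4-yl on the triple-bonded carbon. Going by the values given here, on the two numbers in hand, compound 2 stands highest, with compound 1 as its only neighbour.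

Compound 3 is `CNC(=O)[C@@]12C[C@@H]1[C@@H](n1cnc3c(NC)nc(C#Cc4cc5ccccc5o4)nc31)[C@H](O)[C@@H]2O`, and it differs from compound 2 by 1-benzofuran-2-yl in place of 1-methyl-1H-pyrazol-4-yl on a triple-bonded carbon. Among the compounds with values here, the one step that bears on this change is the one from compound 1 to compound 2, and it ran in the other direction, away from a six-membered aromatic ring of carbon toward the smaller five-membered ring. Since 1-benzofuran-2-yl brings back a six-membered aromatic ring of carbon only, and compound 1 gave 12%, the number for compound 3 is expected to fall back toward that of compound 1, giving an estimated step of a number 15 percentage points lower from compound 2 to compound 3 (beyond the scatter). The value for compound 3 in this assay is therefore estimated at 20%, within a range from 2% to 50%.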

Compound 3, a percentage reported as inhibition, at one concentration (the size of the read-out at that concentration, not a potency): 13%
Compound 3: middle estimate off by 7 percentage points, on the high side; low and high end bracket the measured number.
By their numbers in this assay, from the lowest: compounds 1 and 3 (each within the scatter of the next); then compound 2.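

In this assay, a five-membered aromatic ring with a hetero atom does not by itself keep the higher number of compound 2: 1-benzofuran-2-yl also carries such a ring, yet with it in place of 1-methyl-1H-pyrazol-4-yl there is a drop (a number 22 percentage points lower from compound 2 to compound 3 (beyond the scatter)). The two groups that hold a six-membered aromatic ring of carbon only, 2-methoxyphenyl and 1-benzofuran-2-yl, do not separate (a number 1 percentage points higher from compound 1 to compound 3 (within the scatter)), so among these three compounds only 1-methyl-1H-pyrazol-4-yl stands apart, a pattern with no compound against it but resting on a single higher number. No measured information bears on why the numbers fall this way.

The compounds shown leave open whether a smaller group on the triple-bonded carbon, such as an unsubstituted pyrazole, a pyridine, or a longer chain ending in an amine or a carboxylic acid, would go beyond compound 2 or fall back with compound 1 and compound 3. From the compounds shown here alone, each number is also a reading at one concentration, so how the three compounds compare in potency remains open.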